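The compounds below may be only part of what the source reports. "The series", "measured", "known", "first", "only" and "open" are said of these compounds alone.

Working notes on the series. Compound 3 `CCn1c(-c2cnc(C)nc2)nc2c(N[C@H]3CCN(C(=O)C4CCC4)C3)ncnc21` is measured in an ADME assay (Canis lupus familiaris, strain Beagle) for pharmacokinetics (on this read-out lower numbers stand for narrower distribution and higher numbers for wider distribution into tissues), and gives 1.3 L/kg. Compound 1 `CCn1c(-c2cnc(C)nc2)nc2c(N[C@H]3CCN(C(=O)[C@H]4C[C@@H](OC)C4)C3)ncnc21` differs from compound 3 by methoxy in place of hydrogen on a saturated ring carbon and in this assay compound 1 gives 1.5 L/kg; the step is a 1.2-fold higher number from compound 3 to compound 1 (0.06 log units; within the scatter). Compound 2 `CCn1c(-c2cnc(C)nc2)nc2c(O[C@H]3CCN(C(=O)C4CCC4)C3)ncnc21` stands on a different core from compound 3, and the difference between the two cores is not broken down here. In this assay compound 2 gives 1 L/kg, a number within the scatter of compound 3. Compound 4 `CCn1c(-c2cnc(C)nc2)nc2c(O[C@H]3CCN(C(=O)[C@H]4C[C@@H](OC)C4)C3)ncnc21` is not yet measured; it differs from compound 2 by methoxy in place of hydrogen on a saturated ring carbon, the same change as from compound 3 to compound 1, at the same place. The step of a 1.2-fold higher number from compound 2 to compound 4 (0.08 log units; within the scatter) is expected, because the one earlier occurrence of this change gave a 1.2-fold higher number from compound 3 to compound 1 (0.06 log units; within the scatter). Compound 4 is estimated at 1.2 L/kg, between 0.7 L/kg and 2 L/kg.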

Compound 4, volume of distribution: 0.6 L/kg
Compound 4: middle estimate off by 2.0-fold (0.30 log units), on the high side; measured number outside the range, below it.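

On the core of compound 2, going from cyclobutyl to 3-methoxycyclobutyl in this assay gives a 1.7-fold lower number from compound 2 to compound 4 (0.22 log units; within the scatter). Set beside the earlier occurrence, the two steps do not differ beyond what repeated measurements allow: the same change on two cores in this assay, a 1.2-fold higher number (0.06 log units; within the scatter) from compound 3 to compound 1 and a 1.7-fold lower number (0.22 log units; within the scatter) from compound 2 to compound 4, 1.9-fold (0.28 log units) apart, within the scatter of two such steps. This gives no evidence that the core alters the effect of the change, but two steps, each within the scatter, establish neither a shared size nor a direction for it.

As far as these compounds go, it remains open whether an amine or a carboxylic acid in place of methoxy on the same ring would give a step beyond the scatter on either core. From the compounds shown here alone, how the methoxy change behaves on any further core also remains open.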